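The source may hold more compounds than are shown below. What is called first, only, known or untested is meant among the compounds shown, and "the series" means these compounds.

Measured so far in a functional assay on A549 cells (Homo sapiens) for inhibition, read by MTT assay, with a stated time of 72 h; a lower number here means a stronger inhibitor, a higher number a weaker inhibitor:
- compound 1 `CC1=NN(c2ccc(C)cc2)C(=O)[C@]12C(=O)C=CC[C@H]2c1ccc(C)cc1` gives 7520 nM
- compound 2 `CC1=NN(c2ccc(C)cc2)C(=O)[C@@]12C(=O)C=CC[C@H]2c1ccc(C)cc1` gives 6790 nM

Compound 2 at 6790 nM stands level with compound 1, the two lying within the scatter of each other. Compound 3 `CC1=NN(c2ccc(C)cc2)C(=O)[C@@]12C(=O)C=CC[C@@H]2c1ccc(C)cc1` differs from compound 2 as follows: the two compounds have the same atoms and bonds and differ only in configuration as drawn: 1 of 2 stereo elements differ; a stereocentre at a saturated ring carbon is drawn S in compound 2 and R in compound 3 and nothing else. Within the data shown here, the one measured step of this kind is a 1.1-fold lower number from compound 1 to compound 2 (0.04 log units; within the scatter) and it concerns the other stereo element, so it is only a rough guide. On that step, no change beyond the scatter is expected in this assay in either direction. The estimated step is a 1.0-fold higher number from compound 2 to compound 3 (0.01 log units; within the scatter) on this reading. Compound 3 is expected at 7000 nM with an estimated range of 3500 nM to 14000 nM in this assay.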

Compound 3, half-maximal inhibitory concentration: 4320 nM
Compound 3: middle estimate off by 1.6-fold (0.21 log units), on the high side; the range from low to high includes it.
By their numbers in this assay, from the lowest: compounds 3, 2 and 1 (each within the scatter of the next).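

Inverting the second stereo element, a stereocentre at a saturated ring carbon, gives a 1.6-fold lower number from compound 2 to compound 3 (0.20 log units; within the scatter) in this assay, so this element, like the one inverted earlier, shows no change beyond the scatter. Inverting both stereocentres gives a 1.7-fold lower number from compound 1 to compound 3 (0.24 log units; within the scatter), so the mirror-image pair also stands level in this assay. The comparison concerns configuration alone: the fact that compounds 1 and 3 differ only in the configuration as drawn

Open, as far as these compounds go, is whether configuration remains this silent once an amine or a carboxylic acid is carried on the shared core.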